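The source may report more compounds than this note shows. Statements on the series, on what has been measured and on what is new or still open speak of the compounds shown alone.

Compound 2 `O=C(c1ccc(OCCCN2CC[C@H](NS(=O)(=O)c3ccc(F)cc3)C2)cc1)C1CC1` is the lower of the two numbers recorded in an assay on isolated protein for binding affinity to histamine H2 receptor (Homo sapiens); a higher number here means a weaker inhibitor, a lower number a stronger inhibitor: in this assay compound 2 gives 500 nM, whereas compound 1 `CC(=O)c1ccc(OCCCN2CC[C@H](NS(=O)(=O)c3ccc(C#N)cc3)C2)cc1` gives 2300 nM, a gap that lies beyond the usual scatter. Going by the values given here, the two compounds differ in more than one place, so their values show only that compound 2 is the stronger binder of the pair, not what any single change contributes. Compound 3 `N#Cc1ccc(S(=O)(=O)N[C@H]2CCN(CCCOc3ccc(C(=O)C4CC4)cc3)C2)cc1` arises from compound 2 by one change: cyano in place of fluoro on an aromatic carbon. Among the compounds with values here, no measured pair isolates this substitution, so no direct step is available. Compound 1 carries the same cyano group and stands weaker, but its other difference from compound 2 leaves the matter open. The step from compound 2 to compound 3 is expected to be a modest weakening, a 2.0-fold higher number from compound 2 to compound 3 (0.30 log units; within the scatter). Compound 3 is therefore estimated at 1000 nM, within a range of 350 nM to 3500 nM.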

Compound 3, inhibition constant: 1600 nM
The estimate for compound 3 lay 1.6-fold (0.20 log units) below the measured number; measured number inside the range.
By their numbers in this assay, from the lowest: compound 2; then compounds 3 and 1 (each within the scatter of the next).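

In this assay, the change from 4-fluorophenyl to 4-cyanophenyl now has a reading of its own: with the rest of the molecule unchanged, it gives a 3.2-fold higher number from compound 2 to compound 3 (0.51 log units; beyond the scatter), so the group on this aromatic carbon, para to a large group, does bear on the number. The same cyano series also isolates the other difference between the first two compounds, and cyclopropyl in place of methyl on the carbonyl carbon gives a 1.4-fold lower number from compound 1 to compound 3 (0.16 log units; within the scatter), a step within the scatter, so that change shows no distinct effect here. No measurement at hand accounts for either step. The compounds shown leave open how a chlorine atom, a methoxy group or an amine at this position would compare with fluoro. They also leave open whether the step from fluoro to cyano keeps its size with methyl on the carbonyl carbon.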